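The source may report more compounds than this note shows. Statements on the series, on what has been measured and on what is new or still open speak of the compounds shown alone.

Measured so far:

Compound 1 `CCn1ncc2c(F)cc(-c3ccc(C(CC)(CC)c4nnc(C)[nH]4)c(=O)[nH]3)cc21` gives 90 nM
Compound 2 `CCn1ncc2c(F)cc(-c3ccc(C(CC)(CC)c4ncn(C)n4)c(=O)[nH]3)cc21` gives 96 nM
Compound 3 `CC(C)C(c1noc(=O)[nH]1)c1ccc(-c2ccc3cccc(F)c3c2)[nH]c1=O` gives 41 nM

These three compounds were tested in a functional assay on CHO cells for antagonist activity at prostaglandin E2 receptor EP3 subtype (Homo sapiens), read by cAMP accumulation; on this read-out higher numbers stand for weaker inhibition and lower numbers for stronger inhibition. Compound 2 gives the top number of the small set, but compound 1 cannot be told apart from it, since the two values differ by less than the usual scatter; only compound 3 shows a clearly lower number, beyond the scatter.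

The next compound, compound 4 `CCn1ncc2c(F)cc(-c3ccc(C(CC)(CC)c4nnc[nH]4)c(=O)[nH]3)cc21`, differs from compound 2 in one place: 4H-1,2,4-triazol-3-yl in place of 1-methyl-1H-1,2,4-triazol-3-yl on a saturated chain carbon bound to an aromatic carbon and two saturated chain carbons

Among the compounds with values here, the only measured step that speaks to this change is the one between compound 1 and compound 2, where the pattern of substitution on the triazole was altered and a 1.1-fold higher number from compound 1 to compound 2 (0.03 log units; within the scatter). That step suggests the triazole tolerates changes of this kind without much movement in this assay. Compound 4 removes the methyl altogether, a somewhat larger change than the one measured, so a modest step cannot be ruled out, yet nothing in the data points to a clear direction. The step from compound 2 to compound 4 is therefore expected to be small, a 1.2-fold lower number from compound 2 to compound 4 (0.08 log units; within the scatter), within or close to the scatter. Compound 4 is estimated to give 80 nM in this assay, with a likely range from 35 nM to 180 nM.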

Compound 4, half-maximal inhibitory concentration: 29 nM
Estimate against measurement, compound 4: 2.8-fold (0.44 log units) above, and the stated range ends above it.
By their numbers in this assay, from the lowest: compounds 4 and 3 (each within the scatter of the next); then compounds 1 and 2 (each within the scatter of the next).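

Removing the methyl from the triazole matters in this assay: the change gives a 3.3-fold lower number from compound 2 to compound 4 (0.52 log units; beyond the scatter) and, against the isomer with its methyl on a ring carbon, a 3.1-fold lower number from compound 1 to compound 4 (0.49 log units; beyond the scatter) as well. Moving the methyl between compound 1 and compound 2 had shown nothing beyond the scatter, so among these compounds the triazole tolerates a shift of the methyl, yet the number falls only where no methyl remains. Compound 1 shares the 4H form of the triazole with compound 4, so that form alone does not give the lower number, and nothing measured here says why the methyl has this effect.

As far as these compounds go, it remains open whether any group on that ring carbon raises the number, or only methyl does, since a chloro or an ethyl there would test this. A tetrazole or a carboxylic acid in place of the triazole on the same saturated chain carbon is also untested among the compounds shown.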